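The source may report more compounds than this note shows. Statements on the series, on what has been measured and on what is new or still open speak of the compounds shown alone.

Compound 2, `N#Cc1cc(NS(=O)(=O)c2ccc(N)cc2)ccc1Oc1ccc(Cl)c(C(F)(F)F)c1`, gives 33% in an assay for inhibition of platelet-activating factor acetylhydrolase (Rattus norvegicus), in plasma, with stated times of 30 min and 10 min, tested at 50 nM (on this read-out lower numbers stand for less inhibition and higher numbers for more inhibition at the one concentration tested (going by the name of the read-out)), while compound 1, `CC(=O)Nc1ccc(S(=O)(=O)Nc2ccc(Oc3ccc(Cl)c(C(F)(F)F)c3)c(C#N)c2)cc1`, gives 32% in this assay; the two values lie within the scatter of each other. Compound 3, `CC(=O)NCc1ccc(S(=O)(=O)Nc2ccc(Oc3ccc(Cl)c(C(F)(F)F)c3)c(C#N)c2)cc1`, differs from compound 2 by acetamidomethyl in place of amino on an aromatic carbon. Within the data shown here, the only measured step touching this part of the shared core, a number 1 percentage points higher from compound 1 to compound 2 (within the scatter), was within the scatter. The expected step is therefore no change at the digits printed from compound 2 to compound 3 (within the scatter), with nothing beyond the scatter foreseen in this assay. Compound 3 is estimated at 33%, with a range from 15% to 50%.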

Compound 3, a percentage reported as inhibition, at one concentration (the size of the read-out at that concentration, not a potency): 51%
Estimate against measurement, compound 3: 18 percentage points below; the measured number lies above the stated range.
By their numbers in this assay, from the lowest: compounds 1 and 2 (each within the scatter of the next); then compound 3.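

In this assay, the group on this aromatic carbon, para to a large group, does change the read-out: the step is a number 18 percentage points higher from compound 2 to compound 3 (beyond the scatter) for acetamidomethyl in place of amino, and a number 19 percentage points higher from compound 1 to compound 3 (beyond the scatter) for acetamidomethyl in place of acetamido. Acetamido and amino had not separated, so the acetyl group alone does not account for the higher number seen with acetamidomethyl. Nothing shown here gives a reason for the rise. Still open, from the compounds shown here alone, is whether aminomethyl, or a longer chain ending in acetamido, would keep this higher number.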